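Neutrophil inhibitors: shortening the chain on the aromatic nitrogen

The compounds below may be only part of what the source reports. "The series", "measured", "known", "first", "only" and "open" are said of these compounds alone.

Measured so far:
- compound 1, `CCOC(=O)c1cnn(CC(O)CC)c1NC(=O)NC(C)C`, in a functional assay on cells (Neutrophil, Homo sapiens) for inhibition, with a stated time of 10 min (a higher number here means a weaker inhibitor, a lower number a stronger inhibitor), gives 0.0042 nM
- compound 2, `CCOC(=O)c1cnn(CC(C)O)c1NC(=O)NC(C)C`, in this assay gives 0.00082 nM

Within the data shown here, compound 2 stands lowest of the two numbers in this assay; the only neighbour is compound 1, and the step of a 5.1-fold lower number from compound 1 to compound 2 (0.71 log units; beyond the scatter) lies beyond the scatter. That step removed a methyl two bonds along the chain from the oxygen and left the hydroxyl in place.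

Compound 3, `CCOC(=O)c1cnn(C)c1NC(=O)NC(C)C`, is next for this assay. It differs from compound 2 by hydrogen in place of 1-hydroxyethyl on a saturated chain carbon bound to an aromatic nitrogen, so the whole hydroxyl-bearing chain is gone and only a methyl remains on the aromatic nitrogen. Among the measured compounds shown here, the one measured step, a 5.1-fold lower number from compound 1 to compound 2 (0.71 log units; beyond the scatter), bears only loosely on this: it trimmed the chain but kept the oxygen, whereas here the oxygen leaves as well. For the measured compounds named here, no measured pair shows what loss of the hydroxyl does, so the direction is open. The working expectation for compound 3 is a somewhat higher number, a 3.7-fold higher number from compound 2 to compound 3 (0.56 log units; beyond the scatter), with wide uncertainty. Compound 3 is therefore estimated at 0.003 nM, in the range 0.0005 nM to 0.02 nM.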

Compound 3, half-maximal inhibitory concentration: 0.0018 nM
For compound 3 the middle estimate is 1.7-fold (0.22 log units) above the measured one; measured number inside the range.
By their numbers in this assay, from the lowest: compound 2; then compound 3; then compound 1.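

In this assay, putting hydrogen in place of 1-hydroxyethyl on the saturated chain carbon bound to an aromatic nitrogen gives a 2.2-fold higher number from compound 2 to compound 3 (0.34 log units; beyond the scatter), a modest loss, so the series keeps most of its strength in this assay with only a methyl at this position and without the hydroxyl. Putting hydrogen in place of 1-hydroxypropyl at the same carbon gives a 2.3-fold lower number from compound 1 to compound 3 (0.37 log units; beyond the scatter), which places the methyl compound between the two hydroxyl-bearing compounds, so that removing the chain moves the number in opposite directions depending on which chain leaves, and neither chain length nor presence of the hydroxyl alone orders these three compounds. No supporting measurement bears on why the numbers fall in this order.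

The compounds shown do not separate the contribution of the hydroxyl from that of the carbon chain, since each hydroxyl-bearing chain differs from methyl in both. A plain propyl chain on the aromatic nitrogen, or an amine in place of the hydroxyl on the same chain, would bear on that question.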